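This account rests on a few compounds, and the source may have more. Where it says the series, first, only, none or still open, it means among the compounds named here.

In a functional assay on NCI-H460 cells (Homo sapiens) for inhibition, read by MTT assay, with a stated time of 24 h, tested at 100 ug/mL (a lower number here means less inhibition of growth, a higher number more inhibition of growth at the concentration tested), compound 1 `O=C(CCCCC1CCSS1)Nc1ccccn1` gives 39.3%, while compound 2 `O=C(CCCCC1CCSS1)Nc1ccc(Cl)cn1` gives 58.6%, the higher of the two numbers. Compound 3 `O=C(CCCCC1CCSS1)Nc1ccc(Br)cn1` differs from compound 2 as follows: bromo in place of chloro on an aromatic carbon. This is bromo in place of chloro on an aromatic carbon. Among the compounds with values here, no measured step makes this exact swap. The nearest guide is a number 19.3 percentage points higher from compound 1 to compound 2 (beyond the scatter), seen with chloro in place of hydrogen on an aromatic carbon. Bromo keeps that position substituted, so no step beyond the scatter is expected in this assay. The estimated change is a number 1.4 percentage points higher from compound 2 to compound 3 (within the scatter). For compound 3 the expected value is 60%, with an estimated range from 48% to 72%.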

Compound 3, percent growth inhibition at one concentration: 52%
Estimate against measurement, compound 3: 8 percentage points above; the measured number falls inside the stated range.
By their numbers in this assay, from the lowest: compound 1; then compounds 3 and 2 (each within the scatter of the next).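

In this assay, bromo in place of chloro gives a small step (a number 6.6 percentage points lower from compound 2 to compound 3 (within the scatter)), so the two halogens cannot be told apart at this position. Bromo in place of hydrogen also gives a clear step (a number 12.7 percentage points higher from compound 1 to compound 3 (beyond the scatter)), so the rise is not limited to chloro. Nothing measured here gives a reason for this rise. Still open, going by these compounds, is whether fluoro would give a similar number at this position, and whether a non-halogen group, such as an amine or a methoxy group, would do so too.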